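The source may report more compounds than this note shows. Statements on the series, on what has been measured and on what is new or still open speak of the compounds shown alone.

For the measured compounds named here, in a functional assay on HOP-62 cells (Homo sapiens) for inhibition, read by sulforhodamine B assay (a lower number here means a stronger inhibitor of growth, a higher number a weaker inhibitor of growth), compound 3 (`Clc1cccc(-c2ccc(-c3ccc(-c4nc5ccccc5[nH]4)cc3)cc2)c1`) gives 100000 nM as the highest number of the three measured so far, against compound 2 (`Fc1ccc(-c2ccc(-c3ccc(-c4nc5ccccc5[nH]4)cc3)cc2)cc1`) with 39300 nM and compound 1 (`COc1ccc(-c2ccc(-c3ccc(-c4nc5cc(C)ccc5[nH]4)cc3)cc2)cc1OC`) with 2120 nM on the same read-out. The change to compound 4 (`COc1ccc(-c2ccc(-c3ccc(-c4nc5ccccc5[nH]4)cc3)cc2)cc1OC`), still unmeasured, is 3,4-dimethoxyphenyl in place of 3-chlorophenyl on an aromatic carbon in one place, 3,4-dimethoxyphenyl in place of 3-chlorophenyl. Going by the values given here, the one measured step (a 2.5-fold higher number from compound 2 to compound 3 (0.41 log units; beyond the scatter)) is modest and exchanges other groups, so it offers little guidance. Compound 1 bears more directly, since at 2120 nM it carries the same 3,4-dimethoxyphenyl on a core with one further methyl. A large drop in the number is therefore expected (a 33-fold lower number from compound 3 to compound 4 (1.52 log units; beyond the scatter)) for this exchange. In this assay compound 4 is estimated at 3000 nM (expected range 800 nM to 12000 nM).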

Compound 4, concentration for 50% growth inhibition: 4200 nM
Estimate against measurement, compound 4: 1.4-fold (0.15 log units) below; low and high end bracket the measured number.
By their numbers in this assay, from the lowest: compounds 1 and 4 (each within the scatter of the next); then compound 2; then compound 3.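

In this assay, the 3,4-dimethoxyphenyl group at this position, para to a large group, gives lower numbers than either halogenated phenyl group: a 24-fold lower number from compound 3 to compound 4 (1.38 log units; beyond the scatter) is the larger step, and a 9.4-fold lower number from compound 2 to compound 4 (0.97 log units; beyond the scatter) runs the same way. With hydrogen in place of methyl, a 2.0-fold higher number from compound 1 to compound 4 (0.30 log units; within the scatter) shows that the low number with this group does not depend on the methyl on the core of compound 1. On these data alone, whether a single methoxy group, an amine or a carboxylic acid at this position would give a similarly low number stays open. No evidence is available to explain the effect of this exchange.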